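Thiophene attachment in the methylthio ribonucleoside series

This account rests on a few compounds, and the source may have more. Where it says the series, first, only, none or still open, it means among the compounds named here.

- compound 1 `C#Cc1cn([C@@H]2O[C@H](CO)[C@@H](O)[C@H]2O)c2ncnc(OC)c12` gives 190 nM
- compound 2 `CSc1ncnc2c1c(-c1ccoc1)cn2[C@@H]1O[C@H](CO)[C@@H](O)[C@H]1O` gives 360 nM
- compound 3 `CSc1ncnc2c1c(-c1cccs1)cn2[C@@H]1O[C@H](CO)[C@@H](O)[C@H]1O` gives 1130 nM

In a functional assay on HL-60 cells (Homo sapiens) for antiproliferative activity, read by XTT assay, with a stated time of 72 h (a lower number here means a stronger inhibitor, a higher number a weaker inhibitor), compound 3 has the highest number of the three, beyond the scatter from both others. Compound 4 `CSc1ncnc2c1c(-c1ccsc1)cn2[C@@H]1O[C@H](CO)[C@@H](O)[C@H]1O` carries thiophen-3-yl in place of thiophen-2-yl on an aromatic carbon. For the measured compounds named here, the only measured step bearing on this is a 3.1-fold higher number from compound 2 to compound 3 (0.50 log units; beyond the scatter) and it changes ring and attachment together, so no measured step isolates attachment alone. Going by the values given here, compound 4 shares the 3-yl attachment of compound 2, so a modest move toward a lower number is expected, no larger than that step. The estimate is a 2.1-fold lower number from compound 3 to compound 4 (0.31 log units; beyond the scatter) in this assay as the expected step. Compound 4 is expected at 550 nM within a range of 200 nM to 1400 nM as estimated.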

Compound 4, half-maximal inhibitory concentration: 4590 nM
Beside the measured number, compound 4's estimate is 8.3-fold (0.92 log units) below it; the measured number lies above the stated range.
By their numbers in this assay, from the lowest: compounds 1 and 2 (each within the scatter of the next); then compound 3; then compound 4.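

In this assay, attachment alone now has a measured effect on this aromatic carbon: a 4.1-fold higher number from compound 3 to compound 4 (0.61 log units; beyond the scatter), so among the thiophenes the 3-yl attachment gives the weaker inhibitor. With the 3-yl attachment held, thiophen-3-yl in place of furan-3-yl gives a 13-fold higher number from compound 2 to compound 4 (1.11 log units; beyond the scatter), the largest single-place step in the series and the first to isolate the ring change. No evidence on hand accounts for either step.

As far as these compounds go, whether furan-2-yl would follow the thiophene order remains open. So does how a phenyl ring or an amine would read at this carbon.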